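This account rests on a few compounds, and the source may have more. Where it says the series, first, only, none or still open, it means among the compounds named here.

Measured in a functional assay on A 172 cells (Homo sapiens) for cytotoxicity, read by colorimetric assay and MTT assay; a higher number here means a weaker inhibitor, a lower number a stronger inhibitor:
- compound 1 `COc1ccc2cc(-c3ccccc3)c(O)nc2c1`: 10000 nM
- compound 2 `COc1ccc(-c2cc3cccc(OC)c3nc2O)cc1`: 10000 nM
- compound 3 `CCOC(=O)Cn1c(=O)c(-c2ccc(OC)cc2)cc2c(OC)cc(OC)cc21`: 10000 nM

Compound 3 stands level with compound 1 and compound 2, with no gap between them beyond the usual scatter of repeated measurements. Compound 4 `COc1ccc(-c2cc3c(OC)cc(OC)cc3n(CCCC#N)c2=O)cc1` keeps the core of compound 3 and changes one side chain: 2-cyanoethyl in place of ethoxycarbonyl on a saturated chain carbon bound to an aromatic nitrogen. For the measured compounds named here, no two measured compounds differ in just one place, so this kind of swap has no direct precedent here. Starting from compound 3 at 10000 nM, no step beyond the scatter is expected in this assay, in either direction. The expected change is no change at the digits printed from compound 3 to compound 4 (within the scatter). For compound 4 the estimate is 10000 nM, with an expected range from 4000 nM to 20000 nM.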

Compound 4, half-maximal inhibitory concentration: 10000 nM
Compound 4: the middle estimate sits on the measured number at the digits printed, and the stated range covers the measured number.
By their numbers in this assay, from the lowest: compounds 1, 2, 3 and 4 (each within the scatter of the next).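

For the compounds shown here, measured in this assay the swap of ethoxycarbonyl for 2-cyanoethyl, on a saturated chain carbon bound to an aromatic nitrogen, gives no change at the digits printed from compound 3 to compound 4 (within the scatter) as the first one-place comparison in this set. At this position, then, a nitrile-bearing chain and an ethoxycarbonyl-bearing chain read alike in this cell test. Nothing measured here offers a reason for this result.

On these data alone, whether an amine or a carboxylic acid at the end of this chain would read any differently remains open. So does whether removing the chain altogether, leaving the ring nitrogen with a hydrogen, would matter.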